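A trifluoromethyl group added to compound 1

The source may hold more compounds than are shown below. What is called first, only, known or untested is meant among the compounds shown, and "the series" means these compounds.

In a functional assay on KB cells (Homo sapiens) for antiproliferative activity, read by sulforhodamine B assay, with a stated time of 3 days (a lower number here means that less compound is needed, a higher number that more compound is needed for the effect), compound 1 `CCC1=C(O)c2c(oc(-c3ccccc3)cc2=O)C(CC)(CC)C1=O` gives > 236 uM, which is a limit and not a number. Compound 4 `CCC1=C(O)c2c(oc(-c3cccc(C(F)(F)F)c3)cc2=O)C(CC)(CC)C1=O` differs from it by one change: trifluoromethyl in place of hydrogen on an aromatic carbon, meta to a large group. Two measured changes on the same ring bear on this. Hydroxy in compound 2 `CCC1=C(O)c2c(oc(-c3ccc(O)cc3)cc2=O)C(CC)(CC)C1=O` gives 20.6 uM, a large step of an at least 11-fold lower number from compound 1 to compound 2 (1.05 log units; beyond the scatter). Compound 3 `CCC1=C(O)c2c(oc(-c3ccc(SC)cc3)cc2=O)C(CC)(CC)C1=O`, with methylsulfanyl, gives > 52.1 uM, again a limit. That leaves a step that the two limits leave unreadable from compound 1 to compound 3, while an at least 2.5-fold higher number from compound 2 to compound 3 (0.40 log units; beyond the scatter) is at least modest. Compound 4 has no hydroxy, so a smaller gain than that of compound 2 is expected, giving an expected at least 3.3-fold lower number from compound 1 to compound 4 (0.52 log units; beyond the scatter). For compound 4 the estimate is 70 uM, with an expected range of 20 uM to 240 uM.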

Compound 4, concentration for half-maximal effect: 35.7 uM
For compound 4 the middle estimate is 2.0-fold (0.29 log units) above the measured one; the range from low to high includes it.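

In this assay, trifluoromethyl on an aromatic carbon, meta to a large group, gives an at least 6.6-fold lower number from compound 1 to compound 4 (0.82 log units; beyond the scatter). For the compounds shown here, until now hydroxy was the only change on this ring with a readable gain, so a readable gain here does not need a hydroxy: the entering group has no hydrogen-bond donors. Compound 1 is only a limit, so the full size of this step cannot be read: the limit of > 236 uM in this assay, at which 1 of the 4 values shown sits.

As far as these compounds go, whether trifluoromethyl would give the same gain elsewhere on this ring stays open. So does what an amine or a carboxylic acid would do on this same carbon.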